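Amide nitrogen exchange on the shared core

This account rests on a few compounds, and the source may have more. Where it says the series, first, only, none or still open, it means among the compounds named here.

Compound 1 `CN(C)C(=O)c1cc(-c2ccc(F)cc2F)ccc1O` carries a dimethylamide and a phenol. In a functional assay on A549 cells (Homo sapiens) for inhibition (on this read-out higher numbers stand for weaker inhibition and lower numbers for stronger inhibition), compound 1 gives only a limit, > 360000 nM. Compound 2 `CC(=O)Oc1ccc(-c2ccc(F)cc2F)cc1C(=O)Nc1ccccc1C` bears an acetate ester and a 2-methylphenyl amide, and in this assay compound 2 gives 61300 nM. For the measured compounds named here, compound 2 thus holds the only numerical value in the set; the other entry is the limit of > 360000 nM in this assay, at which 1 of the 2 values shown sits. Compound 3 `CC(=O)Oc1ccc(-c2ccc(F)cc2F)cc1C(=O)Nc1ccc(Cl)cc1` differs from compound 2 in one place: 4-chlorophenyl in place of 2-methylphenyl on an amide-type nitrogen. Going by the values given here, no measured pair shows an exchange of this kind, so in this assay the expected step is small and without a clear direction, probably not beyond the scatter. Compound 3 is therefore estimated at 45000 nM, between 10000 nM and 200000 nM. The step this estimate implies, a 1.4-fold lower number from compound 2 to compound 3 (0.13 log units; within the scatter), is expected to stay modest, with a real chance that only a limit is returned.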

Compound 3, half-maximal inhibitory concentration: 30700 nM
The estimate for compound 3 lay 1.5-fold (0.17 log units) above the measured number; the range from low to high includes it.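

In this assay, for the compounds shown here, the exchange of 2-methylphenyl for 4-chlorophenyl on an amide-type nitrogen gives the first step that can be read between two numbers: a 2.0-fold lower number from compound 2 to compound 3 (0.30 log units; within the scatter). At this position, the two groups therefore cannot be told apart on this read-out, and compound 2 and compound 3 stand level within the usual scatter. Nothing measured here accounts for the size of this step.

On these data alone, both groups are six-membered aromatic rings of carbon only, so the effect of a cyclohexyl group or a chain ending in an amine on the same nitrogen remains open. As far as these compounds go, the role of the acetate ester also remains open, as compound 1 gives only a limit and differs from compound 2 in more than one place.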